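The source may hold more compounds than are shown below. What is called first, only, known or untested is meant among the compounds shown, and "the series" means these compounds.

Measured compounds:
Compound 1, `Cc1ccc(S(=O)(=O)/C(=C/c2ccc(O)c([N+](=O)[O-])c2)C(=O)c2ccc(Cl)cc2)cc1`: 25000 nM
Compound 2, `O=C(/C(=C\c1ccc(O)c([N+](=O)[O-])c1)S(=O)(=O)Cc1ccccc1Cl)c1ccc(Cl)cc1`: 10000 nM
Compound 3, `Cc1ccc(S/C(=C/c2ccc(Oc3ccccc3)cc2)C(=O)c2ccc(Cl)cc2)cc1`: 10000 nM

All three were tested in a functional assay on DU-145 cells (Homo sapiens) for inhibition, read by trypan blue exclusion, with a stated time of 96 h; on this read-out lower numbers stand for stronger inhibition of growth and higher numbers for weaker inhibition of growth. From compound 1 to compound 2 one group is exchanged, (2-chlorobenzyl in place of 4-methylphenyl on a sulfonyl sulfur), and the number moves by a 2.5-fold lower number from compound 1 to compound 2 (0.40 log units; beyond the scatter). Compound 3 differs from compound 1 in its core; that difference is not broken down here. Compound 3 and compound 2 stand level at the digits printed, within the scatter.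

Compound 4, `O=C(/C(=C\c1ccc(Oc2ccccc2)cc1)SCc1ccccc1Cl)c1ccc(Cl)cc1`, has not yet been measured in this assay. Going by the values given here, it carries the same kind of change as the one from compound 1 to compound 2: 2-chlorobenzyl in place of 4-methylphenyl on a sulfur. The change is not the same, since in compound 1 the group sits on a sulfonyl sulfur and in compound 3 on a sulfur, each with a double-bonded chain carbon as its other neighbour. Resting on the step of a 2.5-fold lower number from compound 1 to compound 2 (0.40 log units; beyond the scatter), compound 4 is expected to follow compound 3 by a step of about a 2.0-fold lower number from compound 3 to compound 4 (0.30 log units; within the scatter), and the estimate for compound 4 is 5000 nM, lying between 2000 nM and 15000 nM.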

Compound 4, concentration for 50% growth inhibition: 1000 nM
Estimate against measurement, compound 4: 5.0-fold (0.70 log units) above; the whole stated range lies above it.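

In this assay, putting 2-chlorobenzyl in place of 4-methylphenyl on the sulfur gives a 10-fold lower number from compound 3 to compound 4 (1.00 log units; beyond the scatter), so the change lowers the number on this core as well. Set beside the earlier step, the direction carries over from one core to the other, but the size does not: the same change on two cores in this assay, a 2.5-fold lower number (0.40 log units; beyond the scatter) from compound 1 to compound 2 and a 10-fold lower number (1.00 log units; beyond the scatter) from compound 3 to compound 4, 4.0-fold (0.60 log units) apart, beyond the scatter of two such steps The two cores differ in more than one place, so these pairs do not show which difference goes with the larger step, and two pairs give no rule for other cores in the series.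

The compounds shown leave open whether the lower number goes with the chlorine or with the benzyl group itself, as a plain benzyl group on the sulfur would begin to tell. They also leave open how a longer chain ending in an amine or a carboxylic acid would behave in the same place on either core.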